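A few compounds are considered here, and "the series" means these few. Any claim that something is new, unique, unknown or untested is made for them only; others in the source may bear on it.

Measured in a functional assay on OVCAR-4 cells (Homo sapiens) for inhibition, read by sulforhodamine B assay, with a stated time of 48 h; on this read-out lower numbers stand for stronger inhibition of growth and higher numbers for weaker inhibition of growth:
Compound 1, `CC(C)c1ccc(Nc2ccc3c(OCCCN4CCN(C)CC4)cccc3n2)cc1`: 13900 nM
Compound 2, `CN1CCN(CCCOc2cccc3nc(Nc4ccc(F)c(F)c4)ccc23)CC1`: 6420 nM

Compound 2 gives the lowest number of the two; its nearest neighbour is compound 1, and the step of a 2.2-fold lower number from compound 1 to compound 2 (0.34 log units; beyond the scatter) lies beyond the scatter. Compound 3, `CN1CCN(CCCOc2cccc3nc(Nc4cc(Cl)cc(Cl)c4)ccc23)CC1`, is not yet measured. It differs from compound 2 by 3,5-dichlorophenyl in place of 3,4-difluorophenyl on a nitrogen on an aromatic ring. For the measured compounds named here, the one measured step, a 2.2-fold lower number from compound 1 to compound 2 (0.34 log units; beyond the scatter), concerns a different exchange at the same place and does not isolate this change; no measured pair does. In this assay compound 3 is therefore expected to stay close to compound 2, with a 1.3-fold lower number from compound 2 to compound 3 (0.11 log units; within the scatter) as the expected step. The estimate for compound 3 is 5000 nM, within 2000 nM to 15000 nM.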

Compound 3, concentration for 50% growth inhibition: 2550 nM
Beside the measured number, compound 3's estimate is 2.0-fold (0.29 log units) above it; low and high end bracket the measured number.
By their numbers in this assay, from the lowest: compound 3; then compound 2; then compound 1.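

In this assay, the group on this nitrogen still moves the number when the exchange leaves the heavy-atom count and the hydrogen-bond donor and acceptor counts unchanged: 3,5-dichlorophenyl in place of 3,4-difluorophenyl gives a 2.5-fold lower number from compound 2 to compound 3 (0.40 log units; beyond the scatter), beyond the scatter. Against 4-isopropylphenyl, the same group gives a 5.5-fold lower number from compound 1 to compound 3 (0.74 log units; beyond the scatter), the widest step at this position so far. Nothing measured here bears on the origin of either step.

Open, going by these compounds, is whether the halogen or its placing carries the step, which 3,4-dichlorophenyl and 3,5-difluorophenyl would separate. Also open, on these data alone, is how a pyridyl ring or an aryl carboxylic acid behaves on this nitrogen.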